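The source may report more compounds than this note shows. Statements on the series, on what has been measured and on what is new or still open speak of the compounds shown alone.

Compound 1, `N#Cc1cnc(NCc2cnccc2C(F)(F)F)cc1NC[C@H]1CC[C@H](O)CC1`, gives 2000 nM in an assay on isolated protein for inhibition of protein kinase C delta type (Homo sapiens), read by TR-FRET, with a stated time of 2 h; a higher number here means a weaker inhibitor, a lower number a stronger inhibitor.
Compound 2, `CC(C)(F)c1ncncc1CNc1cc(N[C@H]2CC[C@@H](O)CC2)c(C#N)cn1`, gives 32 nM in this assay.
Compound 3, `N#Cc1cnc(NCc2cncnc2-c2ccccc2)cc1N[C@H]1CC[C@@H](O)CC1`, gives 90 nM in this assay.

Among these three numbers compound 3 stands second highest: compound 2 lies a little below it, while compound 1 lies far above it. The step that leads to compound 4, `N#Cc1cnc(NCc2cncnc2OCC(F)F)cc1N[C@H]1CC[C@@H](O)CC1`, is 2,2-difluoroethoxy in place of phenyl on an aromatic carbon. Going by the values given here, only one measured step touches the same position, a 2.8-fold higher number from compound 2 to compound 3 (0.45 log units; beyond the scatter), and it shows that a small fluorinated group at this carbon gave a lower number than phenyl did. Compound 1 carries its fluorinated group on a different ring and differs elsewhere as well, so its value is no guide to this exchange. Because of the step of a 2.8-fold higher number from compound 2 to compound 3 (0.45 log units; beyond the scatter), a 2,2-difluoroethoxy group at the position of the phenyl is expected to move the number back toward that of compound 2, so a modest step downward in this assay is expected, a 1.6-fold lower number from compound 3 to compound 4 (0.21 log units; within the scatter). Compound 4 is therefore estimated at 55 nM, within a range from 18 nM to 170 nM.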

Compound 4, half-maximal inhibitory concentration: 90 nM
Beside the measured number, compound 4's estimate is 1.6-fold (0.21 log units) below it, and the stated range covers the measured number.
By their numbers in this assay, from the lowest: compound 2; then compounds 3 and 4 (each within the scatter of the next); then compound 1.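

In this assay, replacing the phenyl with 2,2-difluoroethoxy gives no change at the digits printed from compound 3 to compound 4 (within the scatter) and so does not separate these two groups at this aromatic carbon. Going by these compounds alone, the other exchange, with a 2.8-fold higher number from compound 2 to compound 4 (0.45 log units; beyond the scatter) as its step, shows that the lower number of compound 2 is not shared by every small fluorinated group, since 1-fluoro-1-methylethyl remains the only group here that stands apart from the others. Nothing shown accounts for this difference between the two fluorinated groups.

The compounds shown leave open how a plain methoxy or ethoxy group would read at this carbon, and so whether the fluorine atoms of 2,2-difluoroethoxy matter at all. They also leave open how an amine such as dimethylamino or a longer chain such as butyl would compare with 1-fluoro-1-methylethyl.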